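The compounds below may be only part of what the source reports. "The series", "measured", "known", "first", "only" and "open" are said of these compounds alone.

Measured in an ADME assay on microsomes from liver (Mus musculus) for metabolic stability, read by LC-MS, using NADPH, with stated times of 10 min and 30 min; on this read-out lower numbers stand for slow clearance and higher numbers for fast clearance:

- Compound 1 `CCC(=O)N[C@@H]1CCCc2c1cncc2N1C(=O)c2ccc(Cl)cc2[C@@H]1CC`: < 20.2 mL/min/kg
- Compound 2 `CCC(=O)N[C@@H]1CCCc2c1cncc2N1Cc2cc(Cl)ccc2C1=O`: < 20.2 mL/min/kg

For compound 2, the reading of < 20.2 mL/min/kg is a limit of the assay and not a number. Its standing is therefore only partly known: the two measured compounds share (the limit of < 20.2 mL/min/kg in this assay, at which 2 of the 2 values shown sit).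

Compound 3 `CCC(=O)N[C@@H]1CCCc2c1cncc2N1C(=O)c2ccc(Cl)cc2[C@H]1CC` carries ethyl in place of hydrogen on a saturated ring carbon, and the change is ethyl in place of hydrogen on a saturated ring carbon. Going by the values given here, the one measured step that bears on it is the same exchange in the opposite sense, a step that the two limits leave unreadable from compound 1 to compound 2. Its size cannot be read. Compound 1, which bears an ethyl at that place, reads < 20.2 mL/min/kg, again a limit. On that evidence, no step beyond the scatter is expected in this assay, and no direction can be assigned. The expected step is a step that the limit leaves unreadable from compound 2 to compound 3. Compound 3 is estimated at 19 mL/min/kg, with an expected range of 10 mL/min/kg to 40 mL/min/kg.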

Compound 3, clearance: 44.9 mL/min/kg
Estimate against measurement, compound 3: 2.4-fold (0.37 log units) below; measured number outside the range, above it.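

In this assay, ethyl in place of hydrogen on this saturated ring carbon now gives a readable step, an at least 2.2-fold higher number from compound 2 to compound 3 (0.34 log units; beyond the scatter), so the change can matter at this position. The same ethyl gives an at least 2.2-fold higher number from compound 1 to compound 3 (0.34 log units; beyond the scatter), and this ties the higher number to the configuration at this carbon and not to the presence of ethyl alone, because of what separates these two compounds: the fact that compounds 1 and 3 differ only in the configuration as drawn. Both steps start from a limit of the assay and not from a number: the limit of < 20.2 mL/min/kg in this assay, at which 2 of the 3 values shown sit.

Going by these compounds, the step between compound 1 and compound 2 still cannot be read, so the true size of all these differences remains unknown. On these data alone, it also remains open whether a methyl or a propyl at this carbon would show the same dependence on configuration.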